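Series notes: expected binding of compound 4

This account rests on a few compounds, and the source may have more. Where it says the series, first, only, none or still open, it means among the compounds named here.

compound 1 `COC(=O)/C=C/c1cccc(N(Cc2ccc(/C=C/c3c(C)cc(C)cc3C)cc2)C(=O)NC(C)C)c1` gives 431 nM in an assay on isolated protein with Bile acid receptor (Homo sapiens) as the target; on this read-out lower numbers stand for an effect already at smaller amounts and higher numbers for an effect only at larger amounts of compound
compound 2 `COC(=O)/C=C/c1cccc(N(Cc2ccc(/C=C/c3ccc(F)cc3)cc2)C(=O)NC(C)C)c1` gives 348 nM in this assay
compound 3 `COC(=O)/C=C/c1cccc(N(Cc2ccc(-c3ccc(N(C)C)cc3)cc2)C(=O)NC(C)C)c1` gives 162 nM in this assay

Compound 3 holds the lowest of the three numbers in this assay; its steps from compound 2 (a 2.1-fold lower number from compound 2 to compound 3 (0.33 log units; beyond the scatter)) and from compound 1 (a 2.7-fold lower number from compound 1 to compound 3 (0.42 log units; beyond the scatter)) are both beyond the scatter and modest. Compound 4 `COC(=O)/C=C/c1cccc(N(Cc2ccc(-c3c(OC)cccc3OC)cc2)C(=O)NC(C)C)c1` differs from compound 3 by 2,6-dimethoxyphenyl in place of 4-(dimethylamino)phenyl on an aromatic carbon. For the measured compounds named here, no measured pair exchanges one aryl group for another on that aromatic carbon. The two steps that end at compound 3 only show that an aryl group there gave modestly lower numbers than an ethenyl-linked group, while compound 1 and compound 2 (a 1.2-fold lower number from compound 1 to compound 2 (0.09 log units; within the scatter)) sit within the scatter of each other. For the exchange in compound 4 no step beyond the scatter is expected, and the estimated step is a 1.4-fold higher number from compound 3 to compound 4 (0.15 log units; within the scatter). Compound 4 is thus expected at 230 nM, between 90 nM and 650 nM in this assay.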

Compound 4, half-maximal effective concentration: 561 nM
The estimate for compound 4 lay 2.4-fold (0.39 log units) below the measured number; the range from low to high includes it.
By their numbers in this assay, from the lowest: compound 3; then compounds 2, 1 and 4 (each within the scatter of the next).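

For the compounds shown here, the aryl groups on this aromatic carbon are not interchangeable: the only exchange of one aryl group for another, a 3.5-fold higher number from compound 3 to compound 4 (0.54 log units; beyond the scatter), lies beyond the scatter. The advantage of compound 3 over the ethenyl-linked compounds is not shared by 2,6-dimethoxyphenyl, with a 1.6-fold higher number from compound 2 to compound 4 (0.21 log units; within the scatter) and a 1.3-fold higher number from compound 1 to compound 4 (0.11 log units; within the scatter) both within the scatter. No supporting data on hand explain this step.

Still open, from the compounds shown here alone, is whether the step follows the departure of the dimethylamino group or the entry of the methoxy groups. An unsubstituted phenyl or a 4-methoxyphenyl on this aromatic carbon would separate the two.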